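From compound 2 to compound 3: a carbonyl substituent swap

The source may report more compounds than this note shows. Statements on the series, on what has been measured and on what is new or still open speak of the compounds shown alone.

Measured in a functional assay on IMR-32 cells (Homo sapiens) for antiproliferative activity, read by sulforhodamine B assay, with a stated time of 48 h; a lower number here means a stronger inhibitor, a higher number a weaker inhibitor:
- compound 1 `COc1ccc(C[C@@H](O)/C=C/C=C/C(=O)N2CCCCC2)cc1OC` gives 11000 nM
- compound 2 `COc1ccc(C[C@@H](O)/C=C/C=C/C(=O)NCc2ccc(Cl)cc2)cc1OC` gives 15700 nM

Compound 2 has only compound 1 to be compared with, and the two cannot be ranked, since the step between them is a 1.4-fold higher number from compound 1 to compound 2 (0.15 log units; within the scatter). The next compound, compound 3 `COc1ccc(C[C@@H](O)/C=C/C=C/C(=O)N2CCN(C)CC2)cc1OC`, carries 4-methylpiperazin-1-yl in place of (4-chlorobenzyl)amino on a carbonyl carbon. Going by the values given here, no measured compound carries that group, so the evidence is thin. Among the compounds with values here, the only measured step at this carbonyl carbon, a 1.4-fold higher number from compound 1 to compound 2 (0.15 log units; within the scatter), is the one guide, and it suggests that changes here need not move the number in this assay. No step beyond the scatter is therefore expected, in either direction. The expected change is a 1.2-fold lower number from compound 2 to compound 3 (0.08 log units; within the scatter). For compound 3 the estimated value is 13000 nM, with an expected range from 5000 nM to 32000 nM.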

Compound 3, half-maximal inhibitory concentration: 18900 nM
Beside the measured number, compound 3's estimate is 1.5-fold (0.16 log units) below it; measured number inside the range.
By their numbers in this assay, from the lowest: compounds 1, 2 and 3 (each within the scatter of the next).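

In this assay the group on the carbonyl carbon changes again, and neither step leaves the scatter (a 1.2-fold higher number from compound 2 to compound 3 (0.08 log units; within the scatter)) and (a 1.7-fold higher number from compound 1 to compound 3 (0.24 log units; within the scatter)). The first of these steps removes the hydrogen-bond donor and the aromatic ring of carbon only that (4-chlorobenzyl)amino carries, and brings in 4-methylpiperazin-1-yl with its 2 nitrogen atoms, yet compound 2 and compound 3 cannot be told apart, so among these three compounds neither feature shows up in the number. Nothing available accounts for this flat result.

Still open, going by these compounds, is whether a quite different group on this carbonyl carbon, such as morpholin-4-yl or a plain amino group, would also leave the number within the scatter. Also open, on these data alone, is what a change elsewhere on the shared core would do, such as a hydroxyl in place of a methoxy group.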